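Notes on compound 2 and its cyclohexyl analogue, compound 3

The compounds below may be only part of what the source reports. "The series", "measured", "known", "first", "only" and "open" are said of these compounds alone.

Measured so far:
compound 1 `Cc1ccc(S(=O)(=O)N2CC[C@@H](Br)C[C@@H]2c2ccccc2)cc1` — > 100000 nM
compound 2 `Cc1ccc(S(=O)(=O)N2CC=C(Cl)CC2)cc1` — > 100000 nM

Both measured compounds were run in a functional assay on SW1573 cells (Homo sapiens) for antiproliferative activity, read by sulforhodamine B assay, with a stated time of 48 h; a higher number here means a weaker inhibitor of growth, a lower number a stronger inhibitor of growth. In this assay compound 1 gives > 100000 nM, which is a limit of the assay and not a number. In this assay compound 2 gives > 100000 nM, again a limit of the assay. Compound 2 therefore stands at the limit of > 100000 nM in this assay, at which 2 of the 2 values shown sit, and no order between compound 2 and compound 1 can be read from these two values.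

Compound 3 `Cc1ccc(S(=O)(=O)N2CCC(Cl)=CC2C2CCCCC2)cc1` has not yet been measured. It differs from compound 2 by cyclohexyl in place of hydrogen on a saturated ring carbon. For the measured compounds named here, no step between measured compounds is available to gauge a change of this kind; compound 1, which also carries a large group on the saturated ring, sits at the same limit.

The step from compound 2 to compound 3 is expected to be none beyond the scatter, a number no higher from compound 2 to compound 3 (the limit leaves the size open). Compound 3 is therefore expected to give about 100000 nM, within 30000 nM to 300000 nM, most likely reported again only as a limit.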

Compound 3, concentration for 50% growth inhibition: 62000 nM
The estimate for compound 3 lay 1.6-fold (0.21 log units) above the measured number; low and high end bracket the measured number.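

In this assay compound 3 gives 62000 nM, so cyclohexyl on a saturated ring carbon, next to the ring nitrogen, is compatible with a measurable value for growth inhibition. Cyclohexyl in place of hydrogen here gives an at least 1.6-fold lower number from compound 2 to compound 3 (0.20 log units; that floor lies within the scatter); this is only a floor on the change, and on its own it does not separate the pair beyond the scatter. Compound 3 is the only compound shown that has a number and not a limit: the limit of > 100000 nM in this assay, at which 2 of the 3 values shown sit.

Going by these compounds, the true size of the step remains open, since the value of compound 2 is known only as a limit. Also open, on these data alone, is whether cyclohexyl itself matters at this place, or whether a methyl group, a longer alkyl chain or a cyclohexyl ring carrying an amine or a carboxylic acid would give a lower or a higher number.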